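Notes on the diamide series: compound 3 from compound 1

The source may report more compounds than this note shows. Statements on the series, on what has been measured and on what is new or still open speak of the compounds shown alone.

Compound 1 `O=C(Cc1ccccn1)N[C@H]1CCC[C@H](NC(=O)c2cccc(Cl)c2)C1` stands at the top of the measured range in a functional assay on HEK293 cells for antagonist activity at metabotropic glutamate receptor 5 (Homo sapiens), read by FLIPR and calcium flux; a higher number here means a weaker inhibitor, a lower number a stronger inhibitor. Compound 1 reaches only the assay limit there, > 10000 nM, which is a limit rather than a number (the limit of > 10000 nM in this assay, at which 1 of the 2 values shown sits). Compound 2 `O=C(NC1CCCC(NC(=O)c2cccc(Cl)c2)C1)c1cccc(Cl)c1` gives 139 nM in this assay. Compound 3 `Cc1cccc(C(=O)N[C@H]2CCC[C@H](NC(=O)c3cccc(Cl)c3)C2)n1` is not yet measured; it differs from compound 1 by 6-methylpyridin-2-yl in place of (pyridin-2-yl)methyl on a carbonyl carbon. Going by the values given here, no step between measured compounds is known. For compound 3 a step toward stronger inhibition, beyond the scatter, is expected, an at least 6.6-fold lower number from compound 1 to compound 3 (0.82 log units; beyond the scatter). The estimate for compound 3 is 1500 nM, from 200 nM to 10000 nM.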

Compound 3, half-maximal inhibitory concentration: 290 nM
The estimate for compound 3 lay 5.2-fold (0.71 log units) above the measured number; the measured number falls inside the stated range.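

In this assay, 6-methylpyridin-2-yl in place of (pyridin-2-yl)methyl on a carbonyl carbon gives an at least 34-fold lower number from compound 1 to compound 3 (1.53 log units; beyond the scatter). The two groups hold the same atoms, so at this place the way those atoms are joined, not their number, separates the two compounds. The step is only a bound, as compound 1 gives a limit and not a number: the limit of > 10000 nM in this assay, at which 1 of the 3 values shown sits.

Still open, going by these compounds, is whether the step follows the methyl on the ring or the removal of the chain carbon before the ring. Plain pyridin-2-yl on the same carbonyl carbon would separate these two changes.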